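From a fluoromethyl to a methoxymethyl chain end

A few compounds are considered here, and "the series" means these few. Any claim that something is new, unique, unknown or untested is made for them only; others in the source may bear on it.

In a functional assay on HL-60 cells (Homo sapiens) for cytotoxicity, read by WST assay, with a stated time of 48 h (on this read-out higher numbers stand for weaker inhibition and lower numbers for stronger inhibition), compound 1 `COc1cc(C(c2ccc(O)c(OC)c2)[C@@H](C)[C@H](C)CO)ccc1O` gives > 100000 nM, which is a limit and not a number. Within the data shown here, compound 2 `COc1cc(C(c2ccc(O)c(OC)c2)[C@H](C)[C@@H](C)CF)ccc1O` gives 45000 nM, the only actual number so far in this small series. Compound 3 `COC[C@@H](C)[C@H](C)C(c1ccc(O)c(OC)c1)c1ccc(O)c(OC)c1` now replaces the chain end of compound 2, with 2-(methoxymethyl)-1-methylpropyl in place of 2-(fluoromethyl)-1-methylpropyl on a saturated chain carbon bound to two aromatic carbons. Among the measured compounds shown here, one measured step bears on this change, at the same place on the shared core: an at least 2.2-fold lower number from compound 1 to compound 2 (0.34 log units; beyond the scatter). That step concerns the hydroxymethyl and fluoromethyl forms, so it says nothing direct about a methoxymethyl group. The new group carries oxygen, as the hydroxymethyl group of compound 1 does, yet it is not the same group, so a return all the way to the limit of compound 1 is not assumed. A small move towards a higher number in this assay is expected, with no change beyond the scatter. The estimated step is a 1.3-fold higher number from compound 2 to compound 3 (0.12 log units; within the scatter). For compound 3 the expected value is 60000 nM, with an estimated range from 25000 nM to 100000 nM.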

Compound 3, half-maximal inhibitory concentration: 73000 nM
Estimate against measurement, compound 3: 1.2-fold (0.09 log units) below; the range from low to high includes it.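

In this assay, the step of a 1.6-fold higher number from compound 2 to compound 3 (0.21 log units; within the scatter) shows that on a saturated chain carbon bound to two aromatic carbons, the 2-(fluoromethyl)-1-methylpropyl and 2-(methoxymethyl)-1-methylpropyl groups cannot be told apart, even though the entering group carries an oxygen and one hydrogen-bond acceptor. The change of methyl in place of hydrogen on the oxygen gives a second comparison at the same place, an at least 1.3-fold lower number from compound 1 to compound 3 (0.13 log units; that floor lies within the scatter), and this floor does not by itself separate the two compounds. Compound 1 is known only as a limit, so the true size of that step remains unknown: the limit of > 100000 nM in this assay, at which 1 of the 3 values shown sits.

The compounds shown therefore leave open whether the oxygen-bearing chain end differs at all from the hydroxymethyl form once a real number replaces the limit, and whether any group at this place can move the value beyond the scatter from that of compound 2. On these data alone, how an amine, a carboxylic acid or a longer chain such as ethoxymethyl would read at this chain end also remains open.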